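The source may report more compounds than this note shows. Statements on the series, on what has been measured and on what is new or still open speak of the compounds shown alone.

Measured compounds in an assay on membranes from HeLa cells for displacement of a labelled ligand from adenosine receptor A3 (Homo sapiens), read by scintillation counting, with a stated time of 180 min, tested at 1 uM; on this read-out lower numbers stand for less inhibition and higher numbers for more inhibition at the one concentration tested (going by the name of the read-out):
compound 1 `CC1=C(C(=O)CC(C)C)C(c2ccsc2)NC(=O)N1` gives 14%
compound 2 `CC1=C(C(=O)NC(C)C)C(c2ccsc2)NC(=O)N1` gives 1%
compound 3 `CC1=C(C(=O)OCC2CC2)C(c2ccsc2)NC(=O)N1` gives 3%

Compound 3 stands second highest of the three numbers in this assay; its nearest neighbour is compound 2, and the step of a number 2 percentage points higher from compound 2 to compound 3 (within the scatter) is within the scatter. Compound 1 is furthest from it, and the step of a number 11 percentage points lower from compound 1 to compound 3 (beyond the scatter) is beyond the scatter, though modest. The step of a number 13 percentage points lower from compound 1 to compound 2 (beyond the scatter) is of similar size.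

The next compound is compound 4 `CC1=C(C(=O)OCC2CCC2)C(c2ccsc2)NC(=O)N1`. The change from compound 3 reads (cyclobutyl in place of cyclopropyl on a saturated chain carbon bound to an oxygen next to a carbonyl group). Among the compounds with values here, no measured step varies the ring on this saturated chain carbon; the three measured steps all exchange the whole group on the carbonyl carbon, and even those reach only modest size. A step from cyclopropylmethoxy to cyclobutylmethoxy is therefore expected to stay within the scatter, with no direction to assign. For compound 4 in this assay the estimate is 4%, in the range -5% to 14%, which amounts to an expected step of a number 1 percentage points higher from compound 3 to compound 4 (within the scatter).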

Compound 4, a percentage reported as inhibition, at one concentration (the size of the read-out at that concentration, not a potency): 2%
Compound 4: middle estimate off by 2 percentage points, on the high side; the range from low to high includes it.
By their numbers in this assay, from the lowest: compounds 2, 4 and 3 (each within the scatter of the next); then compound 1.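

In this assay, within the data shown here, this is the first variation of the ring itself on a saturated chain carbon bound to an oxygen next to a carbonyl group, and cyclobutyl in place of cyclopropyl gives a number 1 percentage points lower from compound 3 to compound 4 (within the scatter), so the two rings are not told apart at this position. On a carbonyl carbon, cyclobutylmethoxy in place of isopropylamino gives a number 1 percentage points higher from compound 2 to compound 4 (within the scatter), whereas cyclobutylmethoxy in place of isobutyl gives a number 12 percentage points lower from compound 1 to compound 4 (beyond the scatter), so the cyclobutylmethoxy group behaves here like the other two replacements for isobutyl, with the same modest separation from compound 1. No supporting evidence bears on this result.

From the compounds shown here alone, whether cyclopentyl or phenyl on the same chain carbon, or a longer chain carrying the ring, would move the number beyond the scatter remains open. The reading at a single concentration also gives no potency for any of these compounds.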